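The compounds below may be only part of what the source reports. "The series", "measured", "known", "first", "only" and "open" are said of these compounds alone.

Compound 1 `COc1ccc(Cn2c(-c3ccc(C)cc3)c(Br)c(=O)c3cc([N+](=O)[O-])ccc32)cc1` gives 4220 nM.
Compound 2 `Cc1ccc(-c2c(Br)c(=O)c3cc([N+](=O)[O-])ccc3n2C(C)c2ccccc2)cc1` gives 1340 nM.
Compound 3 `CCCCCc1c(Br)c(=O)c2cc([N+](=O)[O-])ccc2n1Cc1ccc(OC)cc1` gives 9510 nM.

All three were tested in an assay on isolated protein for inhibition of alkaline phosphatase, tissue-nonspecific isozyme (Bos taurus), read by spectrophotometry, with stated times of 7 min and 15 min; a lower number here means a stronger inhibitor, a higher number a weaker inhibitor. Compound 1 stands second highest of the three numbers: its nearest neighbour is compound 3 and the furthest is compound 2. Two single changes from compound 1 have been measured. Putting 1-phenylethyl in place of 4-methoxybenzyl on the aromatic nitrogen gives a 3.1-fold lower number from compound 1 to compound 2 (0.50 log units; beyond the scatter). Putting pentyl in place of 4-methylphenyl on an aromatic carbon gives a 2.3-fold higher number from compound 1 to compound 3 (0.35 log units; beyond the scatter). Both steps are modest.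

Compound 4 `COc1ccc(Cn2c(-c3ccc(C)cc3)c(-c3cc(C)cc(C)c3)c(=O)c3cc([N+](=O)[O-])ccc32)cc1` differs from compound 1 at a third place: 3,5-dimethylphenyl in place of bromo on an aromatic carbon. Neither measured step touches this position, so neither bears on it directly; together they only show that single changes around the shared core have moved this assay by modest amounts, downward in one case and upward in the other. Among the compounds with values here, there is no measured precedent for swapping bromo for 3,5-dimethylphenyl here, so the expectation is wide. Compound 4 is expected to give about 4500 nM, with a likely range from 1200 nM to 17000 nM. That estimate amounts to a 1.1-fold higher number from compound 1 to compound 4 (0.03 log units; within the scatter), a change expected to stay close to the scatter.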

Compound 4, half-maximal inhibitory concentration: 4740 nM
For compound 4 the middle estimate is 1.1-fold (0.02 log units) below the measured one; low and high end bracket the measured number.
By their numbers in this assay, from the lowest: compound 2; then compounds 1, 4 and 3 (each within the scatter of the next, the first and the last beyond it).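

In this assay, bromo, a single heavy atom, gives way to 3,5-dimethylphenyl, with 8 heavy atoms and a six-membered aromatic ring of carbon only, yet the result is a 1.1-fold higher number from compound 1 to compound 4 (0.05 log units; within the scatter). Within the data shown here, this is the first measured change at this aromatic carbon, ortho to a 4-methylphenyl group, and it shows that a large increase in size here need not separate the two compounds in this assay, whereas the two earlier single changes, made at other places, both moved the number beyond the scatter. The data shown offer no explanation for why the two compounds cannot be told apart here.

One replacement cannot show whether the position is indifferent to its group in general, and an amine, a carboxylic acid or a longer chain at this carbon could give a different answer. From the compounds shown here alone, it also remains open whether the same swap would leave the number within the scatter on the 1-phenylethyl compound 2 or the pentyl compound 3.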